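Adding a Methoxy Group to an Aminophenyl Chalcone-Pyrazole

A few compounds are considered here, and "the series" means these few. Any claim that something is new, unique, unknown or untested is made for them only; others in the source may bear on it.

Measured compounds:
compound 1, `COc1ccc(-c2cc(/C=C/C(=O)c3ccc(N)cc3)[nH]n2)cc1`, -37%
compound 2, `COc1cc(-c2cc(/C=C/C(=O)c3ccc(Cl)c(Cl)c3)[nH]n2)cc(OC)c1OC`, 47%

Of the compounds shown here, two have been tested in a functional assay on BT-549 cells (Homo sapiens) for cytotoxicity, read by sulforhodamine B assay, with a stated time of 48 h, tested at 10 uM; on this read-out lower numbers stand for a stronger effect and higher numbers for a weaker effect at the one concentration tested. Compound 1 gives -37%, the lowest of the two numbers and therefore the stronger effect; compound 2 gives 47%, a number far higher than that of compound 1, beyond the usual scatter. Within the data shown here, the two structures differ in several places at once, so no single step between them can be followed.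

Compound 3, `COc1ccc(-c2cc(/C=C/C(=O)c3ccc(N)cc3)[nH]n2)cc1OC`, is the one still to be measured. It differs from compound 1 in one place: methoxy in place of hydrogen on an aromatic carbon. Among the measured compounds shown here, no step of this kind has been measured here, so there is nothing to lean on directly. The change is small, and the expectation is that the step from compound 1 to compound 3 in this assay is modest, a number 17 percentage points higher from compound 1 to compound 3 (beyond the scatter), likely within the scatter. Compound 3 is therefore estimated at -20%, in a range from -60% to 30%.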

Compound 3, a percentage reported as activity, at one concentration (the size of the read-out at that concentration, not a potency): -91%
Beside the measured number, compound 3's estimate is 71 percentage points above it; measured number below the stated range.
By their numbers in this assay, from the lowest: compound 3; then compound 1; then compound 2.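

Adding a methoxy group on this aromatic carbon, ortho to a methoxy group and meta to a large group, has a large effect: in this assay the change gives a number 54 percentage points lower from compound 1 to compound 3 (beyond the scatter). Among these compounds, this is the only step here that can be followed in a single place, and it shows that the read-out is sensitive to this position, with the added methoxy group giving the stronger effect at the one concentration tested. Nothing available here explains why so small an addition has so large an effect.

Going by these compounds, only hydrogen and methoxy are compared at this position, so it remains open whether a hydroxyl group, a fluorine atom or an ethoxy group would have a similar effect. On these data alone, it is also open whether the same change would have a similar effect with the two chlorine atoms of compound 2 in place of the amine.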